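The compounds below may be only part of what the source reports. "The series", "measured", "known", "first", "only" and "open" are said of these compounds alone.

Measured compounds:
compound 1 `COc1cc(Cc2nc3c(N)ncnc3n2CCCC(C)C)cc(OC)c1OC`, 69200 nM;
compound 2 `COc1cc(Cc2nc3c(N)nc(F)nc3n2CCOC(C)C)cc(OC)c1OC`, 15800 nM;
compound 3 `CCCCn1c(Cc2cc(OC)c(OC)c(OC)c2Br)nc2c(N)ncnc21`, 25100 nM.

All three numbers come from a functional assay on MCF7 cells (Homo sapiens) for antiproliferative activity; on this read-out higher numbers stand for weaker inhibition and lower numbers for stronger inhibition. Compound 1 stands highest of the three and is the weakest inhibitor of the set: compound 3 sits lower by a margin beyond the usual scatter, and compound 2 lower still, also beyond it. Compound 4 `CCC(C)Cn1c(Cc2cc(OC)c(OC)c(OC)c2)nc2c(N)ncnc21` is not yet measured. It differs from compound 1 in one place: sec-butyl in place of isopentyl on a saturated chain carbon bound to an aromatic nitrogen. Within the data shown here, no measured pair isolates this change, so the expected step in this assay from compound 1 to compound 4 is a small one toward lower numbers, likely not clearly beyond the scatter; the estimated step is a 1.5-fold lower number from compound 1 to compound 4 (0.19 log units; within the scatter). Compound 4 is accordingly estimated at 45000 nM, expected within 15000 nM to 130000 nM.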

Compound 4, half-maximal inhibitory concentration: 61700 nM
The estimate for compound 4 lay 1.4-fold (0.14 log units) below the measured number, and the stated range covers the measured number.
By their numbers in this assay, from the lowest: compounds 2 and 3 (each within the scatter of the next); then compounds 4 and 1 (each within the scatter of the next).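

In this assay, among these compounds, the first single-place step, sec-butyl in place of isopentyl on a saturated chain carbon bound to an aromatic nitrogen, comes to a 1.1-fold lower number from compound 1 to compound 4 (0.05 log units; within the scatter), so the two branched chains cannot be told apart on this read-out. Going from 5 carbons to 4 in this branched chain thus gives no resolved difference. No measurement on hand gives a reason for this result.

Still open, going by these compounds, is whether a much longer chain, a chain ending in an amine or one ending in a carboxylic acid would give a step beyond the scatter at this place. Also open, on these data alone, is whether an unbranched butyl and isopentyl would likewise match on the core of compound 1.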